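The compounds below may be only part of what the source reports. "The series", "measured", "known", "first", "only" and "open" are said of these compounds alone.

Compounds measured so far:
compound 1, `COc1cc(-c2nnc3n2NC(c2cccs2)C(C(=O)c2ccc(C)cc2)S3)cc(OC)c1OC`, 28400 nM
compound 2, `COc1cc(-c2nnc3n2NC(c2cccs2)C(C(=O)c2ccc(F)cc2)S3)cc(OC)c1OC`, 43700 nM
compound 3, `COc1cc(-c2nnc3n2NC(c2ccco2)C(C(=O)c2ccco2)S3)cc(OC)c1OC`, > 100000 nM

The three measured compounds share a common core and were tested in a functional assay on MCF7 cells (Homo sapiens) for cytotoxicity, read by MTT assay, with a stated time of 48 h; a higher number here means a weaker inhibitor, a lower number a stronger inhibitor. Within the data shown here, compound 1 gives 28400 nM and compound 2 gives 43700 nM; the one measured step, a 1.5-fold higher number from compound 1 to compound 2 (0.19 log units; within the scatter), stays within the scatter. Among the measured compounds shown here, compound 3 is the one compound that reaches the limit of this assay, at > 100000 nM, so its standing is a limit rather than a number (the limit of > 100000 nM in this assay, at which 1 of the 3 values shown sits).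

Compound 4, `COc1cc(-c2nnc3n2NC(c2ccco2)C(C(=O)C2CC2)S3)cc(OC)c1OC`, differs from compound 3 by cyclopropyl in place of furan-2-yl on a carbonyl carbon. For the measured compounds named here, no measured step concerns this place: the only measured step, from compound 1 to compound 2, changes a substituent on an aromatic carbon, not the group on the carbonyl carbon, and it was within the scatter in any case. With compound 3 at a limit, there is no number from which a direction can be read. Compound 4 is therefore expected to remain weak in this assay, estimated at 80000 nM with a range from 30000 nM to 200000 nM, which corresponds to an expected step of an at least 1.2-fold lower number from compound 3 to compound 4 (0.09 log units; that floor lies within the scatter), and a fair chance remains that the assay again reports only a limit.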

Compound 4, half-maximal inhibitory concentration: > 100000 nM
Compound 4 gave a limit, no number; the forecaster's own chance of this, stated with the estimate: 50%; middle value at least 1.2-fold (0.09 log units) away from the limit.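

Among these compounds, compound 3 and compound 4 each give only a limit and not a number in this assay, so no step between them can be read: the limit of > 100000 nM in this assay, at which 2 of the 4 values shown sit. The compounds shown leave open whether cyclopropyl in place of furan-2-yl on a carbonyl carbon changes the value at all.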